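Trading a cyclohexyl urea for a pyrrolidine oxamide

This account rests on a few compounds, and the source may have more. Where it says the series, first, only, none or still open, it means among the compounds named here.

Compound 1 `COc1ccc(/C(=C(/CCCl)c2ccccc2)c2ccccc2)cc1`: > 50000 nM
Compound 2 `COc1ccc(/C(=C(/CCNC(=O)NC2CCCCC2)c2ccccc2)c2ccccc2)cc1`: > 50000 nM
Compound 3 `COc1ccc(/C(=C(/CCNC(=O)C(=O)NCc2ccccc2)c2ccccc2)c2ccccc2)cc1`: 11500 nM

In a functional assay on MDA-MB-231 cells (Homo sapiens) for cytotoxicity, read by MTT assay, with a stated time of 72 h (on this read-out lower numbers stand for stronger inhibition and higher numbers for weaker inhibition), compound 1 gives only a limit, > 50000 nM. Compound 2 likewise sits at a limit in this assay, > 50000 nM, so the step that the two limits leave unreadable from compound 1 to compound 2 cannot be sized; both rest at the limit of > 50000 nM in this assay, at which 2 of the 3 values shown sit. Going by the values given here, compound 3 is the one compound of the three that yields a number, 11500 nM, and the step of an at least 4.3-fold lower number from compound 2 to compound 3 (0.63 log units; beyond the scatter) shows that exchanging the urea for an oxamide moved the read-out away from the limit.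

Compound 4 `COc1ccc(/C(=C(/CCNC(=O)C(=O)N2CCCC2)c2ccccc2)c2ccccc2)cc1` differs from compound 2 in one place: (pyrrolidin-1-yl)carbonyl in place of cyclohexylamino on a carbonyl carbon. Among the compounds with values here, this is the same kind of change as the one from compound 2 to compound 3, the urea becoming an oxamide, but with a ring-closed tertiary amide instead of a benzylamide. Within the data shown here, since the only comparable step is an at least 4.3-fold lower number from compound 2 to compound 3 (0.63 log units; beyond the scatter), compound 4 is expected to follow compound 3 in direction and roughly in size, estimated as an at least 2.7-fold lower number from compound 2 to compound 4 (0.44 log units; beyond the scatter). Compound 4 is therefore estimated at 18000 nM, with a range from 7000 nM to 50000 nM, with a fair chance that only a limit is reported.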

Compound 4, half-maximal inhibitory concentration: 48600 nM
For compound 4 the middle estimate is 2.7-fold (0.43 log units) below the measured one, within the range that was stated.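

In this assay, the oxamide alone does not account for the read-out of compound 3: the step of a 4.2-fold higher number from compound 3 to compound 4 (0.63 log units; beyond the scatter) shows that the group on this carbonyl carbon matters, with pyrrolidin-1-yl in place of benzylamino. Set against the two limit compounds, the steps read an at least 1.0-fold lower number from compound 2 to compound 4 (0.01 log units; that floor lies within the scatter) and an at least 1.0-fold lower number from compound 1 to compound 4 (0.01 log units; that floor lies within the scatter), so neither shows a change beyond the scatter. These two steps remain floors and not sizes because compounds 1 and 2 rest at a limit: the limit of > 50000 nM in this assay, at which 2 of the 4 values shown sit.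

The compounds shown leave open whether the benzyl group or the amide hydrogen matters more at this carbonyl carbon. A benzyl(methyl)amino or a methylamino group there would separate the two.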